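A Thiazolyl Sulfonamide Against an Unbroken Limit

The source may hold more compounds than are shown below. What is called first, only, known or untested is meant among the compounds shown, and "the series" means these compounds.

Compound 1 `Cc1ccc(-c2ccccc2S(=O)(=O)N2CCC(N3CCC(C)CC3)CC2)cc1`: in an ADME assay on HCT-116 cells (Homo sapiens) for cytotoxicity, read by CellTiter-Glo, with a stated time of 72 h (on this read-out lower numbers stand for stronger inhibition and higher numbers for weaker inhibition), compound 1 reaches only the limit > 5000 nM.
Compound 2 `CC1CCN(C2CCN(S(=O)(=O)c3ccccc3Br)CC2)CC1`: in this assay compound 2 reaches only the limit > 5000 nM.
Compound 3 `CC1CCN(C2CCN(S(=O)(=O)c3ccccc3-c3ccccc3)CC2)CC1`: in this assay compound 3 reaches only the limit > 5000 nM.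

Compound 2 thus stands at the limit, as do the other two measured compounds. Compound 4 `Cc1nc(Cl)sc1S(=O)(=O)N1CCC(N2CCC(C)CC2)CC1` differs from it by 2-chloro-4-methyl-1,3-thiazol-5-yl in place of 2-bromophenyl on a sulfonyl sulfur. For the measured compounds named here, the steps that bear on this change, a step that the two limits leave unreadable from compound 1 to compound 2 and a step that the two limits leave unreadable from compound 2 to compound 3, are both unreadable because every value sits at the limit of > 5000 nM in this assay, at which 3 of the 3 values shown sit. Going by the values given here, no measured step shows that swapping the ring on the sulfonyl sulfur moves the read-out, so compound 4 is expected to remain at the limit as well. Compound 4 is estimated at 10000 nM, within 3000 nM to 50000 nM. The expected step is a step that the limit leaves unreadable from compound 2 to compound 4, none beyond the scatter.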

Compound 4, half-maximal inhibitory concentration: > 10000 nM
Compound 4 was reported as a limit; the forecaster's own chance of this, stated with the estimate: 80%; the middle value sits exactly at the limit.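

Compound 2 and compound 4 are both reported only as limits, so the step between them cannot be read. The compounds shown leave open whether any group on the sulfonyl sulfur gives a measurable value in this assay.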